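This account rests on a few compounds, and the source may have more. Where it says the series, first, only, none or still open, it means among the compounds named here.

Three compounds with the same core, differing in the group on the carbonyl carbon, have numbers in a functional assay on a cell-free system (Platelet, plasma, Homo sapiens) for inhibition, read by turbidimetry, with a stated time of 3 min; on this read-out higher numbers stand for weaker inhibition and lower numbers for stronger inhibition. The piperidin-1-yl compound, compound 1 `COc1ccc(-n2nc(C(=O)N3CCCCC3)cc2-c2ccc(Cl)cc2)nn1`, gives 41 nM. The (4-chlorophenyl)amino compound, compound 2 `COc1ccc(-n2nc(C(=O)Nc3ccc(Cl)cc3)cc2-c2ccc(Cl)cc2)nn1`, gives 610 nM. The isopentyloxy compound, compound 3 `COc1ccc(-n2nc(C(=O)OCCC(C)C)cc2-c2ccc(Cl)cc2)nn1`, gives 1330 nM, the highest number of the three and so the weakest inhibition.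

Compound 4 `COc1ccc(-n2nc(CCC(=O)N3CCOCC3)cc2-c2ccc(Cl)cc2)nn1` has 2-((morpholin-4-yl)carbonyl)ethyl in place of isopentyloxycarbonyl on an aromatic carbon. Going by the values given here, no measured step makes this exact change, so only the steps on the carbonyl carbon bear on it. Two of these are large, a 15-fold higher number from compound 1 to compound 2 (1.17 log units; beyond the scatter) and a 32-fold higher number from compound 1 to compound 3 (1.51 log units; beyond the scatter), while a 2.2-fold higher number from compound 2 to compound 3 (0.34 log units; beyond the scatter) is modest.

Compound 4 resembles compound 1, at 41 nM, in carrying a non-aromatic six-membered ring on a carbonyl. However, its ring is morpholine rather than piperidine, and an ethyl chain now carries the carbonyl, a change that none of the three compounds tests. Only part of the gap between compound 1 and compound 3 is therefore expected to be recovered, with the number moving lower in this assay. The estimated change is a 4.4-fold lower number from compound 3 to compound 4 (0.65 log units; beyond the scatter). For compound 4 the expected value is 300 nM, within an estimated range of 60 nM to 1500 nM.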

Compound 4, half-maximal inhibitory concentration: 1080 nM
Beside the measured number, compound 4's estimate is 3.6-fold (0.56 log units) below it; the range from low to high includes it.
By their numbers in this assay, from the lowest: compound 1; then compounds 2, 4 and 3 (each within the scatter of the next, the first and the last beyond it).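

In this assay, the 2-((morpholin-4-yl)carbonyl)ethyl group does not stand apart from the two groups that gave the higher numbers: the result is a 1.2-fold lower number from compound 3 to compound 4 (0.09 log units; within the scatter) and a 1.8-fold higher number from compound 2 to compound 4 (0.25 log units; within the scatter), which puts compound 4 level with both compound 2 and compound 3. A six-membered non-aromatic ring on a carbonyl is thus not enough in itself to bring back the low number of compound 1, as the record shows a 26-fold higher number from compound 1 to compound 4 (1.42 log units; beyond the scatter), but that step combines morpholine in place of piperidine with the ethyl chain that now carries the carbonyl, and the data cannot divide the loss between the two. Nothing given here accounts for this result.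

On these data alone, it remains open whether the loss follows the ring or the chain, which (morpholin-4-yl)carbonyl or 2-((piperidin-1-yl)carbonyl)ethyl on the same aromatic carbon could separate. Also open, as far as these compounds go, is how a carboxylic acid or a longer chain bearing the piperidine amide would read at this position.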